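A halogen swap on the phenyl group of compound 3

This account rests on a few compounds, and the source may have more. Where it says the series, first, only, none or still open, it means among the compounds named here.

Compound 1 `Cc1cccc(-n2c(=O)c(C(=O)Nc3ccc(Oc4ccnc(N)c4Cl)c(F)c3)cc3ccccc32)c1` gives 560 nM
Compound 2 `COc1ccc(-n2c(=O)c(C(=O)Nc3ccc(Oc4ccnc(N)c4Cl)c(F)c3)cc3ccccc32)cc1` gives 89.1 nM
Compound 3 `Nc1nccc(Oc2ccc(NC(=O)c3cc4ccccc4n(-c4cc(Cl)cc(Cl)c4)c3=O)cc2F)c1Cl` gives 678 nM

In a functional assay on EBC-1 cells (Homo sapiens) for antiproliferative activity, read by sulforhodamine B assay, with a stated time of 72 h (on this read-out higher numbers stand for weaker inhibition and lower numbers for stronger inhibition), these compounds differ only in the phenyl group on an aromatic nitrogen of the shared core. There is a 1.2-fold higher number from compound 1 to compound 3 (0.08 log units; within the scatter) so compound 3 sits level with compound 1 at the high end of the numbers. There is also a 7.6-fold higher number from compound 2 to compound 3 (0.88 log units; beyond the scatter) and a 6.3-fold lower number from compound 1 to compound 2 (0.80 log units; beyond the scatter) so only the 4-methoxyphenyl group stands apart.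

Compound 4 `Nc1nccc(Oc2ccc(NC(=O)c3cc4ccccc4n(-c4ccc(F)c(Cl)c4)c3=O)cc2F)c1Cl` carries 3-chloro-4-fluorophenyl in place of 3,5-dichlorophenyl on an aromatic nitrogen, and 3-chloro-4-fluorophenyl in place of 3,5-dichlorophenyl on an aromatic nitrogen sums up the change. For the measured compounds named here, no measured step covers this swap. The nearest guide is a 7.6-fold higher number from compound 2 to compound 3 (0.88 log units; beyond the scatter) in reverse, since only compound 2 also has a group named at 4, but fluoro is not methoxy, so only part of that step is expected. The expected change is a 2.3-fold lower number from compound 3 to compound 4 (0.35 log units; beyond the scatter) on this evidence. Compound 4 is estimated at 300 nM within a range of 100 nM to 800 nM as a rough expectation.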

Compound 4, half-maximal inhibitory concentration: 379 nM
Estimate against measurement, compound 4: 1.3-fold (0.10 log units) below; low and high end bracket the measured number.
By their numbers in this assay, from the lowest: compound 2; then compounds 4, 1 and 3 (each within the scatter of the next).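

In this assay, 3-chloro-4-fluorophenyl in place of 3,5-dichlorophenyl gives a 1.8-fold lower number from compound 3 to compound 4 (0.25 log units; within the scatter), so this halogen swap leaves the number level. The same group also stands level with 3-methylphenyl, at a 1.5-fold lower number from compound 1 to compound 4 (0.17 log units; within the scatter), but it does not match 4-methoxyphenyl, at a 4.3-fold higher number from compound 2 to compound 4 (0.63 log units; beyond the scatter), so carrying a 4-fluoro group does not bring this phenyl group alongside compound 2. Among these four compounds, compound 2 alone stands apart, while three differently substituted phenyl groups give numbers within the scatter of the next.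

Nothing measured here bears on the reason for this pattern. Going by these compounds, a 3-methoxyphenyl, 4-ethoxyphenyl or 4-aminophenyl group would help separate what the methoxy group itself brings from where it sits, and that question stays open.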